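The compounds below may be only part of what the source reports. "The series", "measured", "known", "first", "only" and "open" are said of these compounds alone.

Compound 1 `COc1ccc(C(=O)N2CCN(c3nc(N)c4cc(OC)c(OC)cc4n3)CC2)cc1OC` gives 71000 nM in a functional assay on PC-3 cells (Homo sapiens) for inhibition; a lower number here means a stronger inhibitor, a higher number a weaker inhibitor.
Compound 2 `COc1cc2nc(N3CCN(C(=O)c4ccc(C(C)(C)C)cc4)CC3)nc(N)c2cc1OC` gives 47000 nM in this assay.
Compound 3 `COc1cc2nc(N3CCN(S(=O)(=O)c4ccc(Br)cc4)CC3)nc(N)c2cc1OC` gives 20000 nM in this assay.

All three compounds share one core, a piperazine carrying either an amide or a sulfonamide on its far nitrogen. On these numbers compound 3 stands lowest of the three; its nearest neighbour is compound 2 and its furthest compound 1, and both gaps lie beyond the usual scatter of repeated measurements, so compound 3 is the strongest inhibitor of the three in this assay.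

Compound 4 `CCCCc1ccc(-c2ccc(S(=O)(=O)N3CCN(c4nc(N)c5cc(OC)c(OC)cc5n4)CC3)cc2)cc1` differs from compound 3 in one place: 4-butylphenyl in place of bromo on an aromatic carbon. Among the measured compounds shown here, only one measured step exists for comparison, a 1.5-fold lower number from compound 1 to compound 2 (0.18 log units; within the scatter). For the measured compounds named here, that step exchanged one aryl group for another on a carbonyl carbon and stayed within the scatter, so the one swap of an aromatic substituent seen so far did little. Going by the values given here, no measured step replaces a bromo with a 4-butylphenyl on a sulfonyl-bearing ring, so the evidence is indirect. Compound 4 is therefore expected to show a 1.3-fold lower number from compound 3 to compound 4 (0.12 log units; within the scatter), a step of modest size in this assay and quite possibly within the scatter. The estimate for compound 4 in this assay is 15000 nM, with a range from 4000 nM to 50000 nM.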

Compound 4, half-maximal inhibitory concentration: 3400 nM
For compound 4 the middle estimate is 4.4-fold (0.64 log units) above the measured one, and the stated range ends above it.
By their numbers in this assay, from the lowest: compound 4; then compound 3; then compounds 2 and 1 (each within the scatter of the next).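

At this position, an aromatic carbon para to a large group, the site accepts much more than a single bromo atom: in this assay, exchanging bromo for 4-butylphenyl gives a 5.9-fold lower number from compound 3 to compound 4 (0.77 log units; beyond the scatter) and the number falls rather than rises. Among the compounds shown here, this is the first step between compounds differing in one place that goes beyond the scatter, and it comes from a group of 10 heavy atoms, with one further aromatic ring and no hydrogen-bond donors, acceptors or net charge. No measurement shown here explains why this exchange lowers the number.

The compounds shown leave open whether the added ring or the butyl chain accounts for the step: a plain phenyl in that place, or a methyl in place of the butyl chain, would separate the two. They also leave open whether a group of another kind, such as an amine or a carboxylic acid in place of 4-butylphenyl, would lower the number too.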